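Compound 4: cyclohexylamino in place of isopropylamino

The compounds below may be only part of what the source reports. "The series", "measured", "known", "first", "only" and "open" are said of these compounds alone.

In a functional assay on A549 cells (Homo sapiens) for cytotoxicity, read by sulforhodamine B assay (a higher number here means a weaker inhibitor, a lower number a stronger inhibitor), compound 1 `COCCNc1nc(-c2ccccc2)nc2ccccc12` gives 27.5 ug/mL and compound 2 `CN1CCCN(c2nc(-c3ccccc3)nc3ccccc23)CC1` gives 24.1 ug/mL with no separation beyond the scatter (a 1.1-fold lower number from compound 1 to compound 2 (0.06 log units; within the scatter)), while compound 3 `CC(C)Nc1nc(-c2ccccc2)nc2ccccc12` gives 7.53 ug/mL as the lowest of the three numbers. Compound 4 `c1ccc(-c2nc(NC3CCCCC3)c3ccccc3n2)cc1` has cyclohexyl in place of isopropyl on a nitrogen on an aromatic ring. Two modest measured steps arrive at the isopropylamino group (a 3.7-fold lower number from compound 1 to compound 3 (0.56 log units; beyond the scatter); a 3.2-fold lower number from compound 2 to compound 3 (0.51 log units; beyond the scatter)), but neither replaces isopropyl itself, so they bear on this change only loosely. The expected size of a 1.1-fold lower number from compound 3 to compound 4 (0.03 log units; within the scatter) in this assay stays within the scatter, with no direction expected. For compound 4 the estimated value is 7 ug/mL with an expected range (2.5 ug/mL to 20 ug/mL).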

Compound 4, half-maximal inhibitory concentration: 7.23 ug/mL
Compound 4: the middle estimate sits 1.0-fold (0.01 log units) below what was measured; measured number inside the range.
By their numbers in this assay, from the lowest: compounds 4 and 3 (each within the scatter of the next); then compounds 2 and 1 (each within the scatter of the next).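

Replacing isopropyl with cyclohexyl on a nitrogen on an aromatic ring brings in a six-membered non-aromatic ring of carbon only, yet the number in this assay does not separate (a 1.0-fold lower number from compound 3 to compound 4 (0.02 log units; within the scatter)). Cyclohexylamino also stands clear of both earlier amines (a 3.3-fold lower number from compound 2 to compound 4 (0.52 log units; beyond the scatter)) and (a 3.8-fold lower number from compound 1 to compound 4 (0.58 log units; beyond the scatter)), so this level is no longer tied to isopropyl alone. No available evidence bears on the reason for these steps. Open: whether benzylamino, anilino or a cyclohexyl carrying a carboxylic acid holds this level, and whether the match between isopropyl and cyclohexyl extends to other cell lines.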